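This account rests on a few compounds, and the source may have more. Where it says the series, first, only, none or still open, it means among the compounds named here.

Measured so far:
compound 1 `COc1cc(N2C(N)=C(C#N)C(c3cccc([N+](=O)[O-])c3)C3=C2CC(C)(C)CC3=O)cc(OC)c1OC` — 5%
compound 2 `COc1ccccc1C1C(C#N)=C(N)N(c2cc(OC)c(OC)c(OC)c2)C2=C1C(=O)CC(C)(C)C2` — 30%

Among the measured compounds shown here, in a functional assay on Ehrlich cells (Mus musculus) for cytotoxicity, tested at 10 ug/mL (a lower number here means a weaker effect, a higher number a stronger effect of the compound at the concentration tested), compound 2 holds the higher of the two numbers, the single measured step being a number 25 percentage points higher from compound 1 to compound 2 (beyond the scatter). Compound 3 `COc1cc(N2C(N)=C(C#N)C(c3ccccc3Cl)C3=C2CC(C)(C)CC3=O)cc(OC)c1OC` differs from compound 2 in one place: chloro in place of methoxy on an aromatic carbon, which reads 2-methoxyphenyl to 2-chlorophenyl. For the measured compounds named here, no measured step swaps chloro for methoxy; the only one known exchanges the whole aryl group, so it gives little guidance here. A step of no more than the scatter is therefore expected, with a number 5 percentage points lower from compound 2 to compound 3 (within the scatter) as the estimated change. Compound 3 is expected to give 25%, ranging from 5% to 50%.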

Compound 3, a percentage reported as activity, at one concentration (the size of the read-out at that concentration, not a potency): 10%
Estimate against measurement, compound 3: 15 percentage points above; measured number inside the range.
By their numbers in this assay, from the lowest: compounds 1 and 3 (each within the scatter of the next); then compound 2.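

In this assay, swapping only methoxy for chloro on this aromatic carbon gives a number 20 percentage points lower from compound 2 to compound 3 (beyond the scatter), so this single group alone can move the read-out. The 2-chlorophenyl and 3-nitrophenyl groups cannot be told apart, with a number 5 percentage points higher from compound 1 to compound 3 (within the scatter), leaving 2-methoxyphenyl as the only one of the three aryl groups that stands apart. No available data explain why this swap changes the read-out.

From the compounds shown here alone, whether a hydroxy group, an ethoxy group or an amine on this aromatic carbon would behave like methoxy or like chloro remains open. Also unresolved is whether methoxy keeps its effect on another carbon of the ring.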